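A few compounds are considered here, and "the series" means these few. Any claim that something is new, unique, unknown or untested is made for them only; others in the source may bear on it.

Measured so far in an assay on cells with melanin-concentrating hormone receptor 1 (Homo sapiens) as the target, read by radioligand binding; on this read-out lower numbers stand for stronger inhibition and higher numbers for weaker inhibition:
- compound 1 `COCCOCCOc1cccc2ccc(N)nc12`: > 2000 nM (a limit of the assay, not a number)
- compound 2 `CCC(C)COc1cccc2ccc(N)nc12`: 36 nM
- compound 3 `CCCCCOc1cccc2ccc(N)nc12`: 580 nM

Compound 2 holds the lowest of the two numbers; the nearest is compound 3, reached by a 16-fold higher number from compound 2 to compound 3 (1.21 log units; beyond the scatter). Compound 1 stands only at a limit, (the limit of > 2000 nM in this assay, at which 1 of the 3 values shown sits). From compound 1 the steps of an at least 55-fold lower number from compound 1 to compound 2 (1.74 log units; beyond the scatter) and an at least 3.4-fold lower number from compound 1 to compound 3 (0.53 log units; beyond the scatter) both run downward.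

The next compound, compound 4 `CCC#CCOc1cccc2ccc(N)nc12`, differs from compound 2 in one place: but-1-yn-1-yl in place of sec-butyl on a saturated chain carbon bound to an oxygen on an aromatic ring. The step that bears on it most directly is a 16-fold higher number from compound 2 to compound 3 (1.21 log units; beyond the scatter), where butyl replaced sec-butyl at the same place and the number rose strongly. But-1-yn-1-yl, like butyl, is not sec-butyl, so a step in the same direction is expected, though a triple bond has no measured precedent here, which widens the range. The expectation for compound 4 is an 8.3-fold higher number from compound 2 to compound 4 (0.92 log units; beyond the scatter), giving an estimated 300 nM, within 80 nM to 1500 nM.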

Compound 4, half-maximal inhibitory concentration: > 2000 nM
Compound 4 was reported as a limit; the forecaster's own chance of this, stated with the estimate: 10%; middle value at least 6.6-fold (0.82 log units) from the limit.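

At this place, on a saturated chain carbon bound to an oxygen on an aromatic ring, but-1-yn-1-yl gives a clear loss against both saturated groups in this assay: an at least 55-fold higher number from compound 2 to compound 4 (1.74 log units; beyond the scatter), and an at least 3.4-fold higher number from compound 3 to compound 4 (0.53 log units; beyond the scatter). The leaving and entering groups each count 4 heavy atoms, all carbon, so heavy-atom count alone does not separate compound 2 from compound 4; the triple bond and the loss of the branch change together. Compound 4 stands only at a limit, and the step between compound 1 and compound 4 cannot be read: the limit of > 2000 nM in this assay, at which 2 of the 4 values shown sit.

On these data alone, how far the true value of compound 4 lies beyond that limit stays open. Also open, as far as these compounds go, is whether the loss follows the triple bond itself, which a chain with a double bond, such as a butenyl group, would help to settle.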